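Benzyl for isopropyl: expected rise in lipophilicity

The compounds below may be only part of what the source reports. "The series", "measured", "known", "first", "only" and "open" are said of these compounds alone.

Three compounds share a core and differ only in the group on a nitrogen on an aromatic ring. Compound 2 `CC(C)N(C1=NCCN1)c1c(Br)cccc1Br` carries an isopropyl there, compound 1 `CCCCCN(C1=NCCN1)c1c(Br)cccc1Br` a pentyl and compound 3 `CC(C)CCN(C1=NCCN1)c1c(Br)cccc1Br` an isopentyl. In a physicochemical assay for lipophilicity (on this read-out lower numbers stand for lower lipophilicity and higher numbers for higher lipophilicity), compound 2 gives -0.82, the lowest of the three numbers. Compound 1 gives 0.32 and compound 3 gives 0.16. Both of the larger groups lie well above the isopropyl: the step of a number 1.14 log units lower from compound 1 to compound 2 (beyond the scatter) and the step of a number 0.98 log units higher from compound 2 to compound 3 (beyond the scatter) are each beyond the scatter, while the step of a number 0.16 log units lower from compound 1 to compound 3 (within the scatter) is within it.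

Compound 4 `Brc1cccc(Br)c1N(Cc1ccccc1)C1=NCCN1` makes a change of the same kind from compound 2: benzyl in place of isopropyl on a nitrogen on an aromatic ring. The benzyl that enters is larger than the isopropyl that leaves, so in this assay a rise of about the size seen for the pentyl and isopentyl is expected, giving an estimated step of a number 1.12 log units higher from compound 2 to compound 4 (beyond the scatter). Compound 4 is therefore expected to give 0.3, with a range from -0.3 to 0.9.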

Compound 4, distribution coefficient: -0.05
Compound 4: the middle estimate sits 0.35 log units above what was measured; measured number inside the range.
By their numbers in this assay, from the lowest: compound 2; then compounds 4, 3 and 1 (each within the scatter of the next, the first and the last beyond it).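

Benzyl, which brings a six-membered aromatic ring, moves the number in this assay the same way as the two open chains, with a number 0.77 log units higher from compound 2 to compound 4 (beyond the scatter) as its step, so at this nitrogen the rise is not confined to groups without a ring. Among the larger groups the picture is less even: a number 0.21 log units lower from compound 3 to compound 4 (within the scatter) leaves benzyl and isopentyl indistinguishable on this read-out, whereas a number 0.37 log units lower from compound 1 to compound 4 (beyond the scatter) separates benzyl from pentyl. No supporting data are available to explain the sizes of these steps.

The compounds shown leave open how a benzyl with a further group on its ring would behave at this nitrogen. They also leave open whether a chain ending in an amine or a carboxylic acid would follow the same direction.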